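A few compounds are considered here, and "the series" means these few. Any claim that something is new, unique, unknown or untested is made for them only; others in the source may bear on it.

Compound 1 `COc1ccc(CCOc2ccc(-c3c(C)nc(C)c([C@H](OC(C)(C)C)C(=O)O)c3N3CCC(C)(C)CC3)cc2)cc1` is the starting point. In an ADME assay on microsomes from liver (Homo sapiens) for metabolic stability, read by LC-MS, tested at 0.5 uM (on this read-out lower numbers stand for a shorter-lived compound and higher numbers for a longer-lived compound), compound 1 gives > 2 h, and this is a limit of the assay rather than a measured number, so compound 1 sits at the edge of what this assay reports (the limit of > 2 h in this assay, at which 1 of the 3 values shown sits). Two close relatives show what follows when the 4-methoxyphenyl at the end of the chain is replaced. Compound 2 `Cc1nc(C)c([C@H](OC(C)(C)C)C(=O)O)c(N2CCC(C)(C)CC2)c1-c1ccc(OCCc2ccc(F)cc2F)cc1` carries 2,4-difluorophenyl there and in this assay gives 1.08 h; the step is an at least 1.8-fold lower number from compound 1 to compound 2 (0.26 log units; that floor lies within the scatter). Compound 3 `Cc1nc(C)c([C@H](OC(C)(C)C)C(=O)O)c(N2CCC(C)(C)CC2)c1-c1ccc(OCCc2cccnc2)cc1` carries pyridin-3-yl there and in this assay gives 0.367 h; the step is an at least 5.4-fold lower number from compound 1 to compound 3 (0.73 log units; beyond the scatter), and between the two relatives the step is a 2.9-fold lower number from compound 2 to compound 3 (0.47 log units; beyond the scatter).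

Compound 4 `Cc1nc(C)c(CCOc2ccc(-c3c(C)nc(C)c([C@H](OC(C)(C)C)C(=O)O)c3N3CCC(C)(C)CC3)cc2)s1` has not yet been measured. Its change from compound 1 is 2,4-dimethyl-1,3-thiazol-5-yl in place of 4-methoxyphenyl on a saturated chain carbon, two bonds along the chain from an oxygen on an aromatic ring. Both known replacements of the 4-methoxyphenyl lowered the number, and a downward step is expected here because compound 3 showed an at least 5.4-fold lower number from compound 1 to compound 3 (0.73 log units; beyond the scatter) with pyridin-3-yl in the same place. The expected step is an at least 3.3-fold lower number from compound 1 to compound 4 (0.52 log units; beyond the scatter). Compound 4 is therefore estimated to give 0.6 h in this assay, within a range from 0.25 h to 1.5 h.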

Compound 4, half-life: 0.917 h
Estimate against measurement, compound 4: 1.5-fold (0.18 log units) below, within the range that was stated.
By their numbers in this assay, from the lowest: compound 3; then compounds 4 and 2 (each within the scatter of the next). At a limit, above all of these: compound 1.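

In this assay the 2,4-dimethyl-1,3-thiazol-5-yl adds a new kind of group to this place on the chain, a five-membered aromatic ring with 2 hetero atoms, and with it comes an at least 2.1-fold lower number from compound 1 to compound 4 (0.33 log units; beyond the scatter). On these data alone, compound 1 gives > 2 h, which is a limit of the assay and not a number, so this step is a floor and its true size stays unknown: the limit of > 2 h in this assay, at which 1 of the 4 values shown sits. Hetero atoms in the ring do not by themselves set the number: a 2.5-fold higher number from compound 3 to compound 4 (0.40 log units; beyond the scatter) is a clear gap between two rings that both carry them, while a 1.2-fold lower number from compound 2 to compound 4 (0.07 log units; within the scatter) shows that a ring with hetero atoms and a ring of carbon only can give values that cannot be told apart here.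

The compounds shown leave open whether the methoxy group matters in itself, which an unsubstituted phenyl at the end of the chain would address, and whether the two methyl groups on the thiazole matter, which a thiazol-5-yl without them would address. They also leave open how a longer chain between the oxygen and the end ring would read, and they give no reason for the differences seen among these end groups.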